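This account rests on a few compounds, and the source may have more. Where it says the series, first, only, none or still open, it means among the compounds named here.

Measured so far in an ADME assay on a cell-free system (plasma, Homo sapiens) for metabolic stability, read by LC-MS; on this read-out lower numbers stand for a shorter-lived compound and higher numbers for a longer-lived compound:
- compound 1 `CCCCOC(=O)c1cccc(-c2cc(C(=O)Nc3ccncc3)ccc2CN)c1` gives 0.367 h
- compound 2 `CCCCCCOC(=O)c1cccc(-c2cc(C(=O)Nc3ccncc3)ccc2CN)c1` gives 0.833 h
- compound 3 `NCc1ccc(C(=O)Nc2ccncc2F)cc1-c1cccc(C(=O)OCC2CC2)c1` gives 0.3 h

Compound 3 at 0.3 h lies within the scatter of compound 1 at 0.367 h, while compound 2 gives 0.833 h, which lies beyond the scatter of compound 3.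

Compound 4 `CC(C)OCCOC(=O)c1cccc(-c2cc(C(=O)Nc3ccncc3F)ccc2CN)c1` carries isopropoxymethyl in place of cyclopropyl on a saturated chain carbon bound to an oxygen next to a carbonyl group. Cut one bond further out, this reads cyclopropylmethyl to 2-isopropoxyethyl.

Among the compounds with values here, the only measured step on this chain is the modest 2.3-fold higher number from compound 1 to compound 2 (0.36 log units; beyond the scatter), between plain chains, so it guides only loosely. An upward step is expected, estimated as a 1.7-fold higher number from compound 3 to compound 4 (0.22 log units; within the scatter). For compound 4 the estimated half-life is 0.5 h, with an expected range of 0.22 h to 1.1 h.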

Compound 4, half-life: 0.1 h
Estimate against measurement, compound 4: 5.0-fold (0.70 log units) above, and the stated range ends above it.
By their numbers in this assay, from the lowest: compound 4; then compounds 3 and 1 (each within the scatter of the next); then compound 2.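

On a saturated chain carbon bound to an oxygen next to a carbonyl group, a larger group does not by itself give a longer half-life in this assay. Isopropoxymethyl in place of cyclopropyl gives a 3.0-fold lower number from compound 3 to compound 4 (0.48 log units; beyond the scatter) and so runs opposite to the step between plain chains, a 2.3-fold higher number from compound 1 to compound 2 (0.36 log units; beyond the scatter). No measured evidence bears on this drop.

From the compounds shown here alone, the ring leaves and the chain oxygen enters in the same step, so their separate contributions remain open. A plain pentyl chain on the core of compound 3 would separate them.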